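The compounds below may be only part of what the source reports. "The series", "measured", "known", "first", "only" and "open" are said of these compounds alone.

Compound 1 `C#CCOc1cc(/C=C/C(=O)c2ccc(OC)c3c2OC(C)(C)C=C3)ccc1OC` gives > 10000 nM as a limit
Compound 2 `C=CCOc1cc(/C=C/C(=O)c2ccc(OC)c3c2OC(C)(C)C=C3)ccc1OC` gives > 10000 nM as a limit
Compound 3 `C=CC(=O)Oc1cc(/C=C/C(=O)c2ccc(OC)c3c2OC(C)(C)C=C3)ccc1OC` gives 160 nM as a true number

In a functional assay on HepG2 cells (Homo sapiens) for cytotoxicity, read by MTT assay (a lower number here means a stronger inhibitor, a higher number a weaker inhibitor), compound 3 stands at 160 nM and is the only one of the three with a true number. The other two stop at a reporting limit (the limit of > 10000 nM in this assay, at which 2 of the 3 values shown sit), so compound 3 is clearly the strongest of this small set.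

Compound 4 `COc1ccc(/C=C/C(=O)c2ccc(OC)c3c2OC(C)(C)C=C3)cc1OC(=O)c1ccco1` keeps the carbonyl of compound 3 but has furan-2-yl in place of vinyl on a carbonyl carbon. Among the measured compounds shown here, no measured step makes this exact change, so the evidence is indirect. Vinylcarbonyl in place of propargyl brought an at least 62-fold lower number from compound 1 to compound 3 (1.79 log units; beyond the scatter) and vinylcarbonyl in place of allyl brought an at least 62-fold lower number from compound 2 to compound 3 (1.79 log units; beyond the scatter) as well. Both steps are large and both install the carbonyl that compound 4 retains, so a fall all the way back to the limit is not the expected outcome. Neither step separates the carbonyl from the vinyl, however, so some loss remains a reasonable expectation.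

The expected change is a 6.3-fold higher number from compound 3 to compound 4 (0.80 log units; beyond the scatter) in this assay towards weaker inhibition, and this is only an estimate. For compound 4 the estimated value is 1000 nM with an expected range from 150 nM to 8000 nM around it.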

Compound 4, half-maximal inhibitory concentration: 370 nM
Beside the measured number, compound 4's estimate is 2.7-fold (0.43 log units) above it; the range from low to high includes it.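

In this assay, replacing vinyl with furan-2-yl on the carbonyl carbon gives a 2.3-fold higher number from compound 3 to compound 4 (0.36 log units; beyond the scatter), a modest weakening, so the vinyl group is not essential for activity at this position and a five-membered aromatic ring is tolerated there. Compounds 1, 2 and 3 could not show this, as the steps to compound 3 changed the carbonyl and the vinyl together, whereas the (furan-2-yl)carbonyl group now keeps the carbonyl without the vinyl and still gives an at least 27-fold lower number from compound 2 to compound 4 (1.43 log units; beyond the scatter) and an at least 27-fold lower number from compound 1 to compound 4 (1.43 log units; beyond the scatter). These two sizes are minimum sizes rather than exact ones, since compounds 1 and 2 each stop at a limit: the limit of > 10000 nM in this assay, at which 2 of the 4 values shown sit.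

The compounds shown leave open whether any group on the carbonyl carbon would serve equally well, for instance a plain methyl, as in an acetyl group, a longer saturated chain, or a phenyl ring. They also leave open whether the oxygen that links the carbonyl to the aromatic ring matters, which an amide nitrogen in its place could test.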